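The source may hold more compounds than are shown below. What is called first, only, known or untested is meant among the compounds shown, and "the series" means these compounds.

Among the compounds with values here, in a functional assay on MCF7 cells (Homo sapiens) for antiproliferative activity, read by sulforhodamine B assay, with a stated time of 72 h (a lower number here means a stronger inhibitor, a higher number a weaker inhibitor), compound 1 `O=C(/C=C/c1csc2ccccc12)c1ccccc1O` gives 6600 nM and compound 2 `O=C(/C=C/c1csc2ccccc12)c1cc(Br)ccc1O` gives 1040 nM as the lower of the two numbers so far. Within the data shown here, the only measured step is a 6.3-fold lower number from compound 1 to compound 2 (0.80 log units; beyond the scatter) when bromo replaces hydrogen on an aromatic carbon. Compound 3 `COc1ccc(O)c(C(=O)/C=C/c2csc3ccccc23)c1` carries the next change methoxy in place of bromo on an aromatic carbon with methoxy in place of bromo on an aromatic carbon. Among the measured compounds shown here, no measured step involves methoxy, so the single bromo step is the only guide to size. Removing bromo may give back part of a 6.3-fold lower number from compound 1 to compound 2 (0.80 log units; beyond the scatter) and a modest rise in this assay is therefore expected, with the number most likely staying lower than that of compound 1, which gives 6600 nM in the same read-out. The expected step is a 2.4-fold higher number from compound 2 to compound 3 (0.38 log units; beyond the scatter) in that direction. Compound 3 is thus estimated at 2500 nM within an expected range of 800 nM to 7000 nM for now.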

Compound 3, half-maximal inhibitory concentration: 750 nM
Compound 3: middle estimate off by 3.3-fold (0.52 log units), on the high side; the whole stated range lies above it.
By their numbers in this assay, from the lowest: compounds 3 and 2 (each within the scatter of the next); then compound 1.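

Para to a hydroxy group, bromo and methoxy cannot be told apart in this assay, with the exchange giving a 1.4-fold lower number from compound 2 to compound 3 (0.14 log units; within the scatter). Methoxy in place of hydrogen gives an 8.8-fold lower number from compound 1 to compound 3 (0.94 log units; beyond the scatter), so the drop from the number of compound 1 is not confined to bromo and holds for both groups placed here so far. No available evidence explains why these two groups give numbers within the scatter of each other.

Going by these compounds, it remains open whether the lower numbers extend to other kinds of group at this position, such as an amine, a carboxylic acid or a longer chain like butoxy. The compounds shown also leave open whether bromo or methoxy would give a similar step on another carbon of this six-membered aromatic ring.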